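The compounds below may be only part of what the source reports. "The series", "measured", "known", "first", "only" and "open" are said of these compounds alone.

Measured compounds:
Compound 1 `CSc1ccc(NC(=O)N[C@@H]2C3CCN(CC3)[C@@H]2Cc2cccnc2)cc1`: > 10000 nM, a limit of the assay
Compound 2 `O=C(Nc1ccc(Cl)c(Cl)c1)N[C@@H]1C2CCN(CC2)[C@@H]1Cc1cccnc1`: > 10000 nM, a limit of the assay

Both values come from an assay on a protein complex for binding affinity to Neuronal acetylcholine receptor; alpha4/beta2 (Homo sapiens); on this read-out lower numbers stand for stronger inhibition and higher numbers for weaker inhibition. Compound 2 sits at the limit of > 10000 nM in this assay, at which 2 of the 2 values shown sit, so its value is a limit and not a number. For the measured compounds named here, the only measured step, a step that the two limits leave unreadable from compound 1 to compound 2, cannot be read, as both ends sit at the same limit, and the numbers give no position for compound 2 beyond that limit. Compound 3 `O=C(N[C@@H]1C2CCN(CC2)[C@@H]1Cc1cccnc1)c1c[nH]c2ccccc12` differs from compound 2 in one place: 1H-indol-3-yl in place of (3,4-dichlorophenyl)amino on a carbonyl carbon. No measured step bears on this change; the one step shown is unreadable and concerns a different part of the molecule. The expected step, a number no higher from compound 2 to compound 3 (the limit leaves the size open), is therefore taken as none beyond the scatter, in no set direction, because compound 2 shows > 10000 nM, a limit. Compound 3 is estimated at 10000 nM in this assay, with a range of 2000 nM to 50000 nM, and the result may again be a limit.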

Compound 3, inhibition constant: > 10000 nM
Compound 3 was reported as a limit; the forecaster's own chance of this, stated with the estimate: 65%; the middle value lies on the limit itself.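

No new step can be read: the steps from compound 1 and compound 2 to compound 3 all end at a shared limit of the assay, as the evidence shows: the limit of > 10000 nM in this assay, at which 3 of the 3 values shown sit.

The compounds shown leave open how far each lies beyond that limit, and whether 1H-indol-3-yl and (3,4-dichlorophenyl)amino differ at all.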